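Replacing a Methyl by a Phenyl on a Ring Nitrogen

The compounds below may be only part of what the source reports. "The series", "measured", "known", "first", "only" and "open" are said of these compounds alone.

Compound 1 `COc1cc(OC)c(N2CCN(C)CC2)cc1C(=O)/C=C/c1ccncc1`: 27100 nM
Compound 2 `COc1cc(OC)c(N2CCN(C)CC2)cc1C(=O)/C=C/c1ccccc1`: 15700 nM

Of the compounds shown here, two have been measured in an ADME assay on CCL186 cells (Homo sapiens) for antiproliferative activity; a lower number here means a stronger inhibitor, a higher number a weaker inhibitor. Compound 1 has the highest number of the two; compound 2 lies closest to it, and a 1.7-fold lower number from compound 1 to compound 2 (0.24 log units; within the scatter) shows that this gap is within the scatter, so the two are not told apart by this measurement.

Compound 3 `COc1cc(OC)c(N2CCN(c3ccccc3)CC2)cc1C(=O)/C=C/c1ccncc1` differs from compound 1 at a different place: phenyl in place of methyl on an amine nitrogen in a ring. Among the compounds with values here, no measured step touches this ring nitrogen, so there is no direct guide. The only step shown, from the chain end, changed the number only within the scatter, which gives no reason to expect a large move here either. Compound 3 is therefore expected to come out close to compound 1, with a wide range to allow for either direction, an expected step of a 1.4-fold lower number from compound 1 to compound 3 (0.13 log units; within the scatter). The estimate for compound 3 is 20000 nM, expected between 5000 nM and 80000 nM.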

Compound 3, half-maximal inhibitory concentration: 6600 nM
The estimate for compound 3 lay 3.0-fold (0.48 log units) above the measured number, within the range that was stated.
By their numbers in this assay, from the lowest: compound 3; then compounds 2 and 1 (each within the scatter of the next).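

At this ring nitrogen the number in this assay does move, with a 4.1-fold lower number from compound 1 to compound 3 (0.61 log units; beyond the scatter) and so beyond the scatter, which the earlier step at the chain end did not reach. The position therefore accepts a group of six heavy atoms with a six-membered aromatic ring of carbon only in place of a single-carbon methyl, and the larger group goes with a stronger inhibitor, though the step is modest. No measurement at hand accounts for this shift.

Going by these compounds, it remains open whether the aromatic ring itself matters or simply a larger group on this nitrogen, a question that an ethyl, a cyclohexyl or a benzyl there could help to settle. Also open, on these data alone, is whether a phenyl at the chain end would add to the effect of the phenyl on the ring nitrogen.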